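Benzyl in place of 3-bromophenyl on an amide-type nitrogen

This account rests on a few compounds, and the source may have more. Where it says the series, first, only, none or still open, it means among the compounds named here.

Compound 1 `CCCc1ccc(NC(=O)C2CCN(C/C=C/c3ccccc3)CC2)cc1`: 9410 nM
Compound 2 `O=C(Nc1cccc(Br)c1)C1CCN(C/C=C/c2ccccc2)CC1`: 19200 nM

In a functional assay on HepG2 cells (Homo sapiens) for inhibition, read by MTT assay, with a stated time of 72 h (a higher number here means a weaker inhibitor, a lower number a stronger inhibitor), compound 2 gives 19200 nM, the higher of the two numbers and so the weaker inhibitor of the pair. Compound 3 `O=C(NCc1ccccc1)C1CCN(C/C=C/c2ccccc2)CC1` carries benzyl in place of 3-bromophenyl on an amide-type nitrogen. Within the data shown here, the only measured step bearing on this change is a 2.0-fold higher number from compound 1 to compound 2 (0.31 log units; beyond the scatter), which is modest and also alters the group on that nitrogen. A similarly modest change toward a lower number is therefore expected, a 1.4-fold lower number from compound 2 to compound 3 (0.14 log units; within the scatter), though its direction is not firmly set. Compound 3 is estimated at 14000 nM, with a range of 5500 nM to 38000 nM.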

Compound 3, half-maximal inhibitory concentration: > 100000 nM
Compound 3: no number, only a limit (the forecaster's own chance of this, stated with the estimate: 5%); middle value at least 7.1-fold (0.85 log units) from the limit.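

In this assay, this amide-type nitrogen tolerates 3-bromophenyl and 4-propylphenyl with only a modest shift, but benzyl produces a much larger loss, which the earlier pair gave no sign of. The change gives an at least 5.2-fold higher number from compound 2 to compound 3 (0.71 log units; beyond the scatter), and against the other aryl amide it gives an at least 10-fold higher number from compound 1 to compound 3 (1.02 log units; beyond the scatter). Compound 3 carries a limit and not a number, so both steps are minimum sizes: the limit of > 100000 nM in this assay, at which 1 of the 3 values shown sits.

On these data alone, the true size of these steps stays open. So does whether phenethyl, a longer chain on that nitrogen, or a benzyl carrying bromine or propyl would return a measurable number.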